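From phenoxy to (3-chlorophenyl)amino: compound 2 to compound 4

A few compounds are considered here, and "the series" means these few. Any claim that something is new, unique, unknown or untested is made for them only; others in the source may bear on it.

Measured so far in a functional assay (aorta) with Rattus norvegicus as the target (a higher number here means a weaker inhibitor, a lower number a stronger inhibitor), as half-maximal inhibitory concentrations:
- compound 1 `CC1(C)Oc2ccc(C#N)cc2[C@@H](NC(=O)Nc2ccccc2)[C@@H]1O` gives 800 nM
- compound 2 `CC1(C)Oc2ccc(C#N)cc2[C@@H](/N=C(\NC#N)Oc2ccccc2)[C@@H]1O` gives > 100000 nM as a limit of the assay
- compound 3 `CC1(C)Oc2ccc(C#N)cc2[C@@H](NC(=O)NCc2ccccc2)[C@@H]1O` gives 5600 nM

Compound 2 sits at the limit of > 100000 nM in this assay, at which 1 of the 3 values shown sits, and so offers a limit rather than a number as the starting point. The change to compound 4 `CC1(C)Oc2ccc(C#N)cc2[C@@H](/N=C(\NC#N)Nc2cccc(Cl)c2)[C@@H]1O` is (3-chlorophenyl)amino in place of phenoxy on a carbon with a double bond to nitrogen.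

Among the compounds with values here, the only measured step that bears on this is a 7.0-fold higher number from compound 1 to compound 3 (0.85 log units; beyond the scatter), with benzyl in place of phenyl on an amide-type nitrogen. It is modest, and both compound 1 (800 nM) and compound 3 (5600 nM) carry their ring-bearing group on nitrogen and give numbers. On that basis, a large move towards a lower number is expected, though its size is poorly fixed, and it is estimated as an at least 66-fold lower number from compound 2 to compound 4 (1.82 log units; beyond the scatter) in this assay overall. For compound 4 the estimated value is 1500 nM, with an expected range from 250 nM to 9000 nM in this read-out.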

Compound 4, half-maximal inhibitory concentration: 600 nM
For compound 4 the middle estimate is 2.5-fold (0.40 log units) above the measured one; low and high end bracket the measured number.
By their numbers in this assay, from the lowest: compounds 4 and 1 (each within the scatter of the next); then compound 3. At a limit, above all of these: compound 2.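

In this assay, (3-chlorophenyl)amino in place of phenoxy on the carbon with a double bond to nitrogen gives an at least 160-fold lower number from compound 2 to compound 4 (2.22 log units; beyond the scatter), so the group at this place can take the series from a limit to a measured number. The size of the step is therefore open-ended, and its starting point is a limit only: the limit of > 100000 nM in this assay, at which 1 of the 4 values shown sits. The earlier step concerned only a group on an amide-type nitrogen, whereas this one shows that the series also responds strongly to the group at this second place.

As far as these compounds go, the step swaps the oxygen link for a nitrogen link and adds the chlorine together, so the share of each stays open, and a plain phenylamino group at this place would separate them. From the compounds shown here alone, whether a benzylamino group or an alkylamine here would also give a measured number remains unknown.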